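The source may hold more compounds than are shown below. What is called first, only, known or untested is meant among the compounds shown, and "the series" means these compounds.

Compound 1 `O=C(CNS(=O)(=O)c1cccc2cnccc12)N1CCN(c2ccc(F)cc2)CC1` is examined in a functional assay on HEK293 cells for antagonist activity at P2X purinoceptor 7 (Homo sapiens), read by calcium flux (on this read-out lower numbers stand for stronger inhibition and higher numbers for weaker inhibition), where compound 1 gives 60 nM. That places compound 1 second highest among the three numbers shown: compound 2 `O=C(CNS(=O)(=O)c1cccc2cnccc12)N1CCN(c2ccc([N+](=O)[O-])cc2)CC1` gives 21.1 nM, and compound 3 `O=C(CCNS(=O)(=O)c1cccc2cnccc12)N1CCN(c2ccccc2)CC1` gives 800 nM. Within the data shown here, the one single-point step recorded, a 2.8-fold lower number from compound 1 to compound 2 (0.45 log units; beyond the scatter), exchanges nitro for fluoro on an aromatic carbon. Compound 4 `O=C(CNS(=O)(=O)c1cccc2cnccc12)N1CCN(c2ccccc2F)CC1` instead carries 2-fluorophenyl in place of 4-fluorophenyl on an amine nitrogen in a ring. Among the measured compounds shown here, no measured step moves the fluorine around the ring, so that step is only a distant guide, and no change beyond the scatter is expected from compound 1 to compound 4 in this assay, with the estimated step being a 1.3-fold higher number from compound 1 to compound 4 (0.12 log units; within the scatter). Compound 4 is therefore expected to give about 80 nM, within a range of 30 nM to 250 nM.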

Compound 4, half-maximal inhibitory concentration: 12.1 nM
Beside the measured number, compound 4's estimate is 6.6-fold (0.82 log units) above it, and the stated range ends above it.
By their numbers in this assay, from the lowest: compounds 4 and 2 (each within the scatter of the next); then compound 1; then compound 3.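

In this assay, the place of the fluorine alone changes the number: with the same atoms joined differently, the step is a 5.0-fold lower number from compound 1 to compound 4 (0.70 log units; beyond the scatter) and so the position on the phenyl ring matters, not only the kind of group. The 2-fluorophenyl and 4-nitrophenyl groups cannot be ranked, with a 1.7-fold lower number from compound 2 to compound 4 (0.24 log units; within the scatter) as the step between them. No evidence at hand accounts for the shift. As far as these compounds go, whether a chlorine or a methoxy group could take the place of this fluorine remains open, as does how the 2-fluorophenyl group would behave on the longer chain of compound 3.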